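The compounds below may be only part of what the source reports. "The series", "measured", "known", "first", "only" and "open" are said of these compounds alone.

Measured compounds:
Compound 1, `CO[C@@H]1CC=C2NN(c3ccc(C)cc3)C(=O)C[C@]2(C)O1` — in a functional assay on A549 cells (Homo sapiens) for inhibition, read by sulforhodamine B assay, with a stated time of 48 h (a lower number here means a stronger inhibitor, a higher number a weaker inhibitor), compound 1 gives 21500 nM.
Compound 2, `CO[C@@H]1CC=C2NN(c3ccc(C)cc3)C(=O)C[C@]2(c2ccncc2)O1` — in this assay compound 2 gives 5900 nM.
Compound 3, `COc1cc(OC)cc(N2NC3=CC[C@@H](OC)O[C@@]3(C)CC2=O)c1` — in this assay compound 3 gives 6150 nM.

Compounds 1 and 2 share one core; the change between them is pyridin-4-yl in place of methyl on a saturated ring carbon, and the step it made is a 3.6-fold lower number from compound 1 to compound 2 (0.56 log units; beyond the scatter). Compound 3 carries a different core, and the difference between the two cores is not broken down here. The value of compound 3 sits within the scatter of that of compound 2, so no order between the two can be read from these numbers.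

Compound 4, `COc1cc(OC)cc(N2NC3=CC[C@@H](OC)O[C@@]3(c3ccncc3)CC2=O)c1`, has not yet been measured in this assay. Its relation to compound 3 is pyridin-4-yl in place of methyl on a saturated ring carbon, which is the same kind of change as that from compound 1 to compound 2. The surroundings of the place are described differently in the two cases: in the first it is a six-membered non-aromatic ring with 1 oxygen, next to the ring oxygen and next to the ring atom that bears a fused ring, two ring bonds from the ring atom that bears a methoxy group; in the second it is a six-membered non-aromatic ring with 2 nitrogen, two ring bonds from the ring nitrogen, three ring bonds from the ring nitrogen, and three ring bonds from the ring atom that bears a large group.

Going by the values given here, the expected step from compound 3 to compound 4 is estimated at a 3.1-fold lower number from compound 3 to compound 4 (0.49 log units; beyond the scatter), resting on the single earlier step of a 3.6-fold lower number from compound 1 to compound 2 (0.56 log units; beyond the scatter) seen with compound 1 and compound 2, with some allowance because a 3.6-fold lower number from compound 1 to compound 2 (0.56 log units; beyond the scatter) is the only step that supports it. Compound 4 is therefore expected to give about 2000 nM, with a range from 800 nM to 5000 nM.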

Compound 4, half-maximal inhibitory concentration: 6220 nM
Compound 4: the middle estimate sits 3.1-fold (0.49 log units) below what was measured; the whole stated range lies below it.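

In this assay, replacing methyl with pyridin-4-yl on the saturated ring carbon did not repeat its earlier result on the second core, where the step is a 1.0-fold higher number from compound 3 to compound 4 (0.00 log units; within the scatter). Set beside the step on the first core, the same change gives a different outcome on each: the same change on two cores in this assay, a 3.6-fold lower number (0.56 log units; beyond the scatter) from compound 1 to compound 2 and a 1.0-fold higher number (0.00 log units; within the scatter) from compound 3 to compound 4, 3.7-fold (0.57 log units) apart, beyond the scatter of two such steps This shows that the lower number seen with the core of compound 1 cannot be assumed for the core of compound 3, but with only one pair on each core it does not show which difference between the cores matters, or whether other replacements for methyl would part in the same way.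

The compounds shown leave open whether a phenyl ring, a longer chain, an amine or a carboxylic acid on that saturated ring carbon would give a step on one core that carries over to the other in this assay. They also leave open whether the gap between the two steps follows the aryl group on the ring nitrogen as a whole or a single part of it, such as one methoxy group.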